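Polyyne fatty acids: tetrayne to enyne step

This account rests on a few compounds, and the source may have more. Where it says the series, first, only, none or still open, it means among the compounds named here.

Measured so far:
compound 1, `O=C(O)CCCCCCCC#CC#CC#CC#C[C@@H](O)CO` — 6.7 ug/mL in a functional assay on SK-N-SH cells (Homo sapiens) for cytotoxicity; a higher number here means that more compound is needed for the effect, a lower number that less compound is needed
compound 2, `C[C@H](O)C#CC#CC#CC#CCCCCCCCC(=O)O` — 1.4 ug/mL in this assay

For the measured compounds named here, compound 2 holds the lowest of the two numbers so far, with compound 1 as its only neighbour; the single measured step runs a 4.8-fold lower number from compound 1 to compound 2 (0.68 log units; beyond the scatter) and concerns a hydroxy group on a saturated chain carbon, not the unsaturated chain.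

The next compound, compound 3, is `C[C@H](O)/C=C/C#CC#CC#CCCCCCCCC(=O)O`. It differs from compound 2 as follows: 3-hydroxybut-1-en-1-yl in place of 3-hydroxybut-1-yn-1-yl on a triple-bonded carbon. The four-triple-bond chain of compound 2 thus becomes a chain with three triple bonds and one double bond, everything else unchanged.

Going by the values given here, no measured pair speaks to this kind of change. The step from compound 1 to compound 2 alters a hydroxy group on the saturated part of the chain and gives no guide to exchanging a triple bond for a double bond. With nothing to push the number either way, the working expectation for compound 3 is a step of a 1.4-fold higher number from compound 2 to compound 3 (0.15 log units; within the scatter), that is, no change beyond the usual scatter. Compound 3 is therefore estimated at 2 ug/mL, with a range from 0.8 ug/mL to 5 ug/mL.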

Compound 3, concentration for half-maximal effect: 3.7 ug/mL
For compound 3 the middle estimate is 1.9-fold (0.27 log units) below the measured one; the range from low to high includes it.
By their numbers in this assay, from the lowest: compound 2; then compounds 3 and 1 (each within the scatter of the next).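

For the compounds shown here, on a triple-bonded carbon whose other neighbour is a triple-bonded carbon, the exchange of 3-hydroxybut-1-yn-1-yl for 3-hydroxybut-1-en-1-yl is the first change in the unsaturated chain, and in this assay it gives a 2.6-fold higher number from compound 2 to compound 3 (0.42 log units; beyond the scatter), so this position responds to the triple bond becoming a double bond. Setting 3-hydroxybut-1-en-1-yl in place of the 3,4-dihydroxybut-1-yn-1-yl group of compound 1 gives a 1.8-fold lower number from compound 1 to compound 3 (0.26 log units; within the scatter), whereas the loss of the hydroxy group alone gave a 4.8-fold lower number from compound 1 to compound 2 (0.68 log units; beyond the scatter), so the double bond takes back enough of that step to leave compound 3 and compound 1 inseparable in this read-out. Nothing available explains why the double bond raises the number from the value of compound 2.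

Still open, as far as these compounds go, is whether the same step appears in a 3,4-dihydroxybut-1-en-1-yl compound, which would show if the exchange holds with both hydroxy groups in place. The series shown also leaves open how the other end of the chain contributes, for instance a methyl ester or a primary amide in place of the carboxylic acid.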